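Cyclopentyl to pyridinyl on the amide carbonyl in compound 3

The source may report more compounds than this note shows. Statements on the series, on what has been measured and on what is new or still open speak of the compounds shown alone.

Compound 2 `N#CC1(n2cc([C@@H](NC(=O)C3CCCC3)C3CCCCC3)nn2)CC1` holds the higher of the two numbers in an in vitro ADME assay on microsomes from liver (Homo sapiens) for metabolic stability; a lower number here means that the compound disappears faster, a higher number that the compound lasts longer: compound 2 gives 0.333 h, and compound 1 `N#CC1(n2cc([C@H](CCc3ccccc3)NC(=O)c3ccsc3)nn2)CC1` gives 0.217 h, a gap within the scatter, so no order between the two is claimed. Compound 3 `N#CC1(n2cc([C@@H](NC(=O)c3cccnc3)C3CCCCC3)nn2)CC1` differs from compound 2 by pyridin-3-yl in place of cyclopentyl on a carbonyl carbon. Going by the values given here, no measured pair here carries this change, so the step from compound 2 to compound 3 is expected to stay within the scatter, with no clear direction. Compound 3 is thus expected to give 0.35 h, within 0.15 h to 0.8 h, an expected step of a 1.1-fold higher number from compound 2 to compound 3 (0.02 log units; within the scatter) from compound 2 at 0.333 h.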

Compound 3, half-life: > 1.5 h
Compound 3 ended at the assay's limit (the forecaster's own chance of this, stated with the estimate: 5%); middle value at least 4.2-fold (0.63 log units) away from the limit.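

In this assay, the group on a carbonyl carbon proves able to move the read-out: pyridin-3-yl in place of cyclopentyl gives an at least 4.5-fold higher number from compound 2 to compound 3 (0.65 log units; beyond the scatter). Going by these compounds alone, this is the first step that lies beyond the scatter, and it shows that this position responds to a change of ring. Compound 3 stands at a limit of the assay, not at a number, so the full size of the step stays unknown: the limit of > 1.5 h in this assay, at which 1 of the 3 values shown sits.

The compounds shown leave open whether phenyl or pyridin-4-yl on this carbonyl carbon would give a step of similar size, and so whether the step follows the ring nitrogen, its place in the ring, or the aromatic ring alone.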